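This account rests on a few compounds, and the source may have more. Where it says the series, first, only, none or still open, it means among the compounds named here.

Measured in an in vitro ADME assay on microsomes from liver (Homo sapiens) for metabolic stability, tested at 1 uM; on this read-out higher numbers stand for a longer-lived compound and lower numbers for a shorter-lived compound:
- compound 1 `COc1cccc(CN2C(=O)C(C3=NS(=O)(=O)c4cc(NS(C)(=O)=O)ccc4N3)=C(O)[C@@H]3[C@H]4CC[C@H](C4)[C@@H]32)c1`: > 1 h
- compound 2 `Cc1ccc(CN2C(=O)C(C3=NS(=O)(=O)c4cc(NS(C)(=O)=O)ccc4N3)=C(O)[C@@H]3[C@H]4CC[C@H](C4)[C@@H]32)cc1F`: > 1 h

In this assay compound 2 gives > 1 h, which is a limit and not a number. Compound 3 `CS(=O)(=O)Nc1ccc2c(c1)S(=O)(=O)N=C(C1=C(O)[C@@H]3[C@H]4CC[C@H](C4)[C@@H]3N(CC3CCCCC3)C1=O)N2` differs from it by cyclohexyl in place of 3-fluoro-4-methylphenyl on a saturated chain carbon bound to an amide-type nitrogen in a ring, with cyclohexyl in place of 3-fluoro-4-methylphenyl at the same place. For the measured compounds named here, the one measured step there, a step that the two limits leave unreadable from compound 1 to compound 2, gives no size to work from, so no shift beyond the scatter is expected. The expected change is a number no higher from compound 2 to compound 3 (the limit leaves the size open). For compound 3 the estimated half-life is 1 h, with an expected range from 0.4 h to 2.5 h.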

Compound 3, half-life: 0.733 h
Compound 3: the middle estimate sits 1.4-fold (0.13 log units) above what was measured; the range from low to high includes it.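

In this assay, cyclohexyl at this place, on a saturated chain carbon bound to an amide-type nitrogen in a ring, gives the first half-life that is a number and not a limit. Replacing either aromatic ring with it gives an at least 1.3-fold lower number from compound 2 to compound 3 (0.13 log units; that floor lies within the scatter) and an at least 1.3-fold lower number from compound 1 to compound 3 (0.13 log units; that floor lies within the scatter), so neither floor establishes a real loss. The true size of both steps stays open because compound 1 and compound 2 stand only at a limit: the limit of > 1 h in this assay, at which 2 of the 3 values shown sit.

Going by these compounds, how far the aromatic compounds really lie from compound 3 remains unknown. Also open, on these data alone, is how a piperidine ring or a carboxylic acid at this place would read in this assay.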